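Pyridin-4-yl for 4-Fluorophenyl on the Aromatic Nitrogen

The source may report more compounds than this note shows. Statements on the series, on what has been measured and on what is new or still open speak of the compounds shown alone.

Of the compounds shown here, three of a shared core have been measured in an in vitro assay on BHK cells for displacement of a labelled ligand from Alpha-1A adrenergic receptor (Bos taurus), read by scintillation counting, with a stated time of 20 min; a lower number here means a stronger inhibitor, a higher number a weaker inhibitor. Compound 1 `CN1CCC(c2cn(-c3ccncc3)c3ccc(-c4ccnn4C)cc23)CC1` gives 19 nM, and compound 2 `CN1CCC(c2cn(-c3ccncc3)c3ccc(-c4cnn(C)c4)cc23)CC1` gives 38 nM; the one listed step between them, a 2.0-fold higher number from compound 1 to compound 2 (0.30 log units; within the scatter), is the only paired comparison available. Compound 3 `CN1CCC(c2cn(-c3ccc(F)cc3)c3ccc(-c4ccncc4)cc23)CC1` gives 10 nM and stands lowest of the three numbers, within the scatter of compound 1 but beyond it relative to compound 2.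

Compound 4 `CN1CCC(c2cn(-c3ccncc3)c3ccc(-c4ccncc4)cc23)CC1` differs from compound 3 in one place: pyridin-4-yl in place of 4-fluorophenyl on an aromatic nitrogen. For the measured compounds named here, no measured pair changes the group on this aromatic nitrogen, so no step bears directly on the change. The step from compound 1 to compound 2 concerns a different position and was within the scatter; the values of compound 1 and compound 3, which differ at two positions, also lie within the scatter of each other. On that evidence the replacement of 4-fluorophenyl by pyridin-4-yl is expected to leave this assay essentially unchanged, with the step of a 1.4-fold higher number from compound 3 to compound 4 (0.15 log units; within the scatter) anticipated to stay within the scatter. Compound 4 is therefore estimated at 14 nM, with a range from 5 nM to 40 nM.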

Compound 4, inhibition constant: 24 nM
Beside the measured number, compound 4's estimate is 1.7-fold (0.23 log units) below it; the measured number falls inside the stated range.
By their numbers in this assay, from the lowest: compounds 3, 1, 4 and 2 (each within the scatter of the next, the first and the last beyond it).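

In this assay, for the compounds shown here, this is the first pair to change the group on the aromatic nitrogen of the five-membered ring, and pyridin-4-yl in place of 4-fluorophenyl gives a modest step toward a weaker inhibitor that lies beyond the scatter (a 2.4-fold higher number from compound 3 to compound 4 (0.38 log units; beyond the scatter)). Going by these compounds alone, with pyridin-4-yl held on that nitrogen, compound 4 also links the two earlier compounds through the group on the aromatic carbon, and neither step leaves the scatter (a 1.6-fold lower number from compound 2 to compound 4 (0.20 log units; within the scatter); a 1.3-fold higher number from compound 1 to compound 4 (0.10 log units; within the scatter)), so pyridin-4-yl, 1-methyl-1H-pyrazol-4-yl and 1-methyl-1H-pyrazol-5-yl are not told apart at that place, and the change on the nitrogen is the only single-place step here that exceeds the scatter. No measurement offered here accounts for that step.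

The compounds shown leave open whether the step from 4-fluorophenyl to pyridin-4-yl keeps its size when either methylpyrazolyl group stands on the aromatic carbon. Within the data shown here, they also leave open how this assay responds to an unsubstituted phenyl, a pyridin-3-yl or a simple methyl group on the aromatic nitrogen, since only two groups have been compared there.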